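Dropping Two Halogens from an Aryl Group

The source may hold more compounds than are shown below. What is called first, only, known or untested is meant among the compounds shown, and "the series" means these compounds.

Compound 1: `Cc1cc(=O)n(-c2ccccc2C(F)(F)F)nc1C(=O)Nc1ccc(Oc2ncnc3ccsc23)cc1`, 5550 nM
Compound 2: `O=C(Nc1ccc(Oc2ncnc3ccsc23)c(F)c1)c1nn(-c2ccc(F)c(Cl)c2)ccc1=O`, 6630 nM

In a functional assay on MCF7 cells (Homo sapiens) for cytotoxicity, read by MTT assay, with a stated time of 72 h (a higher number here means a weaker inhibitor, a lower number a stronger inhibitor), compound 1 gives 5550 nM, and compound 2 gives 6630 nM. The two numbers lie within the scatter of each other, so compound 2 cannot be placed above or below compound 1. Compound 3 `O=C(Nc1ccc(Oc2ncnc3ccsc23)c(F)c1)c1nn(-c2ccccc2)ccc1=O` differs from compound 2 by phenyl in place of 3-chloro-4-fluorophenyl on an aromatic nitrogen. Among the compounds with values here, no measured pair shows this change, so the step in this assay is expected to stay small, if anything toward a higher number, a 1.2-fold higher number from compound 2 to compound 3 (0.08 log units; within the scatter). Compound 3 is therefore estimated at 8000 nM, between 3000 nM and 20000 nM.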

Compound 3, half-maximal inhibitory concentration: 12400 nM
For compound 3 the middle estimate is 1.6-fold (0.19 log units) below the measured one, within the range that was stated.
By their numbers in this assay, from the lowest: compounds 1, 2 and 3 (each within the scatter of the next, the first and the last beyond it).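

In this assay, within the data shown here, phenyl in place of 3-chloro-4-fluorophenyl on an aromatic nitrogen gives a 1.9-fold higher number from compound 2 to compound 3 (0.27 log units; within the scatter), the first pair here to isolate this position. Dropping the chlorine and fluorine together therefore gives no readable difference, and neither halogen can be credited with a role at this position. No measurement here bears on this result. On these data alone, it remains open whether a methoxy group or an amine on this phenyl, or a pyridyl ring in its place, would move the number beyond the scatter. As far as these compounds go, whether a simple methyl on this nitrogen would do the same also remains open.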